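A few compounds are considered here, and "the series" means these few. Any claim that something is new, unique, unknown or untested is made for them only; others in the source may bear on it.

In an ADME assay on Huh-7 cells (Homo sapiens) for cytotoxicity, read by MTT assay, with a stated time of 72 h (a higher number here means that more compound is tolerated, a lower number that less compound is tolerated), compound 1 `C/C(=C\c1c[nH]c2ccccc12)C(N)=O` reports > 10000 nM as a limit of the assay and not as a number. Among the measured compounds shown here, compound 2 `C/C(=C\c1c[nH]c2cc(C)ccc12)C(=O)Nc1ccc(C(C)(C)C)cc1` gives 25600 nM as the only true number so far, and it stands alone with no second number to rank it against. Compound 3 `C/C(=C\c1c[nH]c2cc(C(C)C)ccc12)C(=O)Nc1ccc(C(C)(C)C)cc1` follows from compound 2 by one exchange on the shared core, isopropyl in place of methyl on an aromatic carbon with isopropyl in place of methyl on an aromatic carbon. For the measured compounds named here, no measured step covers such an exchange, so the only anchor is compound 2 at 25600 nM for this read-out. The estimated 1.3-fold lower number from compound 2 to compound 3 (0.11 log units; within the scatter) is expected to stay within the usual scatter, with a slight lean toward less compound tolerated. Compound 3 is expected at 20000 nM with an estimated range from 8000 nM to 50000 nM in this assay once measured.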

Compound 3, half-maximal cytotoxic concentration: 24800 nM
For compound 3 the middle estimate is 1.2-fold (0.09 log units) below the measured one; the range from low to high includes it.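

In this assay this position now has its first readable step, a 1.0-fold lower number from compound 2 to compound 3 (0.01 log units; within the scatter), for isopropyl in place of methyl on an aromatic carbon. Compound 2 alone, as a single number, could show nothing about how the read-out responds to a change here. The pair shows that going from the 1 heavy atom of methyl to the 3 heavy atoms of isopropyl, with no ring, no hydrogen-bond donor or acceptor and no net charge on either side, stays within the scatter.

How an amine, a carboxylic acid or a longer chain on this aromatic carbon would read stays open, since only these two alkyl groups are shown here. Compound 1 gives no further anchor, as it differs in more than one place and carries a limit and not a number: the limit of > 10000 nM in this assay, at which 1 of the 3 values shown sits.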